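This account rests on a few compounds, and the source may have more. Where it says the series, first, only, none or still open, it means among the compounds named here.

In a functional assay on aorta (Rattus norvegicus, strain Sprague-Dawley) (a higher number here means that more compound is needed for the effect, a lower number that less compound is needed), compound 1 `Cc1ccccc1COc1nc2c(cc1-c1nc(N)cc(N)n1)c(C)nn2-c1ccccc1` gives 290 nM while compound 2 `Cc1nn(-c2ccccc2)c2nc(OCc3ccccc3F)c(-c3nc(N)c(N)c(N)n3)cc12` gives 960 nM as the higher of the two numbers, a gap beyond the usual scatter. Compared with compound 2, compound 3 `Cc1nn(-c2ccccc2)c2nc(OCc3ccccc3F)c(-c3nc(N)c(NC(=O)OC4CCCC4)c(N)n3)cc12` shows cyclopentyloxycarbonyl in place of hydrogen on a nitrogen on an aromatic ring with cyclopentyloxycarbonyl in place of hydrogen on a nitrogen on an aromatic ring. For the measured compounds named here, no measured pair shows this change, so in this assay no step beyond the scatter is expected, with only a slight lean towards a lower number. The estimated change is a 1.9-fold lower number from compound 2 to compound 3 (0.28 log units; within the scatter) on this reading. Compound 3 is expected at 500 nM with an estimated range from 120 nM to 2000 nM once measured.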

Compound 3, half-maximal effective concentration: > 100000 nM
Compound 3 ended at the assay's limit; the forecaster's own chance of this, stated with the estimate: 5%; middle value at least 200-fold (2.30 log units) from the limit.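

For the compounds shown here, compounds 1 and 2 gave no step at this position, so this is the first reading of a change on this nitrogen. In this assay, putting cyclopentyloxycarbonyl in place of hydrogen on a nitrogen on an aromatic ring, which turns amino into (cyclopentyloxycarbonyl)amino, gives an at least 100-fold higher number from compound 2 to compound 3 (2.01 log units; beyond the scatter) and so is far from neutral here. Compound 3 stands at a limit of the assay and not at a number: the limit of > 100000 nM in this assay, at which 1 of the 3 values shown sits.

On these data alone, whether a methyl, an acetyl or an ethoxycarbonyl group on this nitrogen would give a number short of that limit remains open. As far as these compounds go, the true number of compound 3 also remains open.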